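Swapping the aryl group on the piperazine nitrogen

A few compounds are considered here, and "the series" means these few. Any claim that something is new, unique, unknown or untested is made for them only; others in the source may bear on it.

Compounds measured in a functional assay on HL-60 cells (Homo sapiens) for inhibition, read by MTT assay, with a stated time of 72 h; on this read-out higher numbers stand for weaker inhibition and lower numbers for stronger inhibition:
compound 1, `Cc1nc(-c2ccc(F)cc2)c(C(=O)N2CCN(c3ccc(C(=O)C(C)C)cc3)CC2)o1`: "not active" (no number reported)
compound 2, `Cc1nc(-c2ccccc2)c(C(=O)N2CCN(c3c(C)cccc3C)CC2)o1`: 146 nM
compound 3, `Cc1ccc(N2CCN(C(=O)c3oc(C)nc3-c3ccccc3)CC2)cc1`: > 1000 nM

Compound 3 stands at a limit of this assay, (the limit of > 1000 nM in this assay, at which 1 of the 3 values shown sits), so no single number is known for it; compound 1 likewise has no number. Compound 2 gives 146 nM in this assay. As far as these compounds go, compound 4, `Cc1nc(-c2ccccc2)c(C(=O)N2CCN(c3ccccc3Cl)CC2)o1`, is untested, and differs from compound 3 by 2-chlorophenyl in place of 4-methylphenyl on an amine nitrogen in a ring. Going by the values given here, no measured step matches this change; the only step available, an at least 6.8-fold higher number from compound 2 to compound 3 (0.83 log units; beyond the scatter), shows that replacing 2,6-dimethylphenyl with 4-methylphenyl weakened inhibition. Since compound 4 carries a different substituted phenyl again, a partial recovery is expected, though the number may still sit at the limit. Compound 4 is estimated at 400 nM (range 100 nM to 2000 nM), which would mean an at least 2.5-fold lower number from compound 3 to compound 4 (0.39 log units; beyond the scatter).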

Compound 4, half-maximal inhibitory concentration: 124 nM
Estimate against measurement, compound 4: 3.2-fold (0.51 log units) above; low and high end bracket the measured number.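

In this assay, 2-chlorophenyl on the ring amine nitrogen restores inhibition that 4-methylphenyl lacks (an at least 8.0-fold lower number from compound 3 to compound 4 (0.90 log units; beyond the scatter)). That step has no upper bound, as compound 3 sits at a limit and not at a number: the limit of > 1000 nM in this assay, at which 1 of the 4 values shown sits. Replacing 2,6-dimethylphenyl with 2-chlorophenyl leaves the read-out unchanged (a 1.2-fold lower number from compound 2 to compound 4 (0.07 log units; within the scatter)), so these two groups cannot be told apart here.

The compounds shown leave open whether the gain follows the chlorine itself or its place on the ring. A 4-chlorophenyl or 2-methylphenyl group on this nitrogen would separate the two.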